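A few compounds are considered here, and "the series" means these few. Any claim that something is new, unique, unknown or untested is made for them only; others in the source may bear on it.

Compounds measured so far: compound 1 `COc1ccc(-c2nc3cnccn3c2Nc2cc(OC)c(OC)c(OC)c2)cc1O` with 50000 nM, compound 2 `COc1cc(Nc2c(-c3ccc(Cl)cc3)nc3cnccn23)cc(OC)c1OC` with 32000 nM, and compound 3 `COc1ccc(Nc2c(-c3ccc(Cl)cc3)nc3cnccn23)cc1` with 45000 nM, all in an ADME assay on Vero cells (Chlorocebus sabaeus) for cytotoxicity, read by MTT assay; a lower number here means that less compound is tolerated, a higher number that more compound is tolerated.

Compound 1 and compound 2 share a core and differ in one place: 3-hydroxy-4-methoxyphenyl in place of 4-chlorophenyl on an aromatic carbon. That change gave a 1.6-fold higher number from compound 2 to compound 1 (0.19 log units; within the scatter). Compound 3 and compound 2 differ in their cores, and that difference is not broken down here; their values in this assay lie close to one another.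

Compound 4 `COc1ccc(Nc2c(-c3ccc(OC)c(O)c3)nc3cnccn23)cc1` has not yet been measured. It stands to compound 3 as compound 1 stands to compound 2: 3-hydroxy-4-methoxyphenyl in place of 4-chlorophenyl on an aromatic carbon. The surroundings are described slightly differently, the ring atom bearing a group of 9 heavy atoms in one case and a large group in the other, so this is the same kind of change rather than the same one. Because the earlier instance produced only a 1.6-fold higher number from compound 2 to compound 1 (0.19 log units; within the scatter), compound 4 is expected to give a 1.2-fold higher number from compound 3 to compound 4 (0.09 log units; within the scatter) in this assay. The estimated value for compound 4 in this assay is 55000 nM, expected to fall between 30000 nM and 100000 nM.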

Compound 4, concentration lethal to 50% of the cells: 62000 nM
Compound 4: middle estimate off by 1.1-fold (0.05 log units), on the low side; the range from low to high includes it.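

Exchanging 4-chlorophenyl for 3-hydroxy-4-methoxyphenyl on an aromatic carbon gave a 1.4-fold higher number from compound 3 to compound 4 (0.14 log units; within the scatter) in this assay. Set beside the earlier instance, the change shows no detectable dependence on the core: the same change on two cores in this assay, a 1.6-fold higher number (0.19 log units; within the scatter) from compound 2 to compound 1 and a 1.4-fold higher number (0.14 log units; within the scatter) from compound 3 to compound 4, 1.1-fold (0.05 log units) apart, within the scatter of two such steps. Since each step lies within the scatter, the two cores agree only in showing no clear effect of this change in this assay; this does not show that the change raises the number, nor that other cores in the series would behave alike.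

The compounds shown leave open whether a different group in place of 3-hydroxy-4-methoxyphenyl, such as an amine or a carboxylic acid, would move the number beyond the scatter.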